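Indole hydrazide series: bromo-indole replaced by methyl-indole

The source may hold more compounds than are shown below. What is called first, only, known or untested is meant among the compounds shown, and "the series" means these compounds.

Measured so far in a functional assay on MCF7 cells (Homo sapiens) for cytotoxicity; a lower number here means a stronger inhibitor, a higher number a weaker inhibitor:
Compound 1 `COc1ccc(Cn2cc(/C=N\NC(=O)c3c[nH]c4ccccc34)c3ccccc32)cc1` gives 12400 nM.
Compound 2 `COc1ccc(Cn2cc(/C=N\NC(=O)c3c[nH]c4ccc(Br)cc34)c3cc(OC)ccc32)cc1` gives 3100 nM.
Compound 3 `COc1ccc2c(c1)c(/C=N\NC(=O)c1c[nH]c3ccc(Br)cc13)cn2Cc1ccc(Cl)cc1` gives 29100 nM.

Compound 3 stands highest of the three numbers in this assay, with compound 1 nearest and compound 2 furthest. Within the data shown here, the only single-point step measured, a 9.4-fold higher number from compound 2 to compound 3 (0.97 log units; beyond the scatter), concerns a different part of the molecule and does not touch the hydrazide end. Compound 4 `COc1ccc2c(c1)c(/C=N\NC(=O)c1cn(C)c3ccccc13)cn2Cc1ccc(Cl)cc1` arises from compound 3 by 1-methyl-1H-indol-3-yl in place of 5-bromo-1H-indol-3-yl on a carbonyl carbon. Among the measured compounds shown here, no measured step bears on this change directly; compounds 1 and 2 differ at the bromine of the 5-bromo-1H-indol-3-yl group but also elsewhere, so their values show only that the unbrominated compound 1 gives the higher number. The expected step of a 1.4-fold higher number from compound 3 to compound 4 (0.14 log units; within the scatter) is therefore near or within the scatter, leaning weaker. Compound 4 is estimated at 40000 nM, range 13000 nM to 120000 nM.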

Compound 4, half-maximal inhibitory concentration: 99100 nM
Beside the measured number, compound 4's estimate is 2.5-fold (0.39 log units) below it; low and high end bracket the measured number.
By their numbers in this assay, from the lowest: compound 2; then compound 1; then compound 3; then compound 4.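

In this assay, among these compounds, the first measured step at the hydrazide end is a 3.4-fold higher number from compound 3 to compound 4 (0.53 log units; beyond the scatter), so the group on the carbonyl carbon does affect the number, and this change moves it toward weaker inhibition. The change removes the bromine and adds the methyl in one step, so the step cannot be divided between the two. Nothing available accounts for the step.

Which of the two edits carries the step remains open. Also open, as far as these compounds go, is how a 5-chloro-1H-indol-3-yl group or a pyridine ring on the carbonyl carbon would compare.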